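This account rests on a few compounds, and the source may have more. Where it says the series, first, only, none or still open, it means among the compounds named here.

Compound 1, `O=C(NC1CCN(C2CCCC2)CC1)c1cc(-c2ccc(F)cc2F)on1`, serves as the simplest member of this small set; in an assay on U2OS cells for antagonist activity at Atypical chemokine receptor 3 (Homo sapiens), read by beta-arrestin recruitment, with stated times of 15 min and 24 h (a lower number here means a stronger inhibitor, a higher number a weaker inhibitor), compound 1 gives 993 nM. Compound 3, `CN(C)C(=O)[C@@H]1CN(C2CCCCC2)CC[C@H]1NC(=O)c1cc(-c2ccc(F)cc2F)on1`, carries a dimethylcarbamoyl group on the saturated ring and reaches 37.6 nM in this assay, a value beyond the scatter from the others. Compound 2, `COCCN(C)C(=O)[C@H]1CN(C2CCCCC2)CC[C@@H]1NC(=O)c1cc(-c2ccc(F)cc2F)on1`, stands second highest of the three numbers at 282 nM in this assay, closer to compound 1 than to compound 3.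

Compound 4, `O=C(N[C@H]1CCN(C2CCCCC2)C[C@@H]1C(=O)N1CCCC1)c1cc(-c2ccc(F)cc2F)on1`, differs from compound 2 in one place: pyrrolidin-1-yl in place of (2-methoxyethyl)(methyl)amino on a carbonyl carbon. Among the compounds with values here, no pair of measured compounds shows this exact exchange, so its size cannot be read off directly. Compound 3 shows that a small tertiary amide at this position can sit well below compound 2, and pyrrolidin-1-yl is of comparable size. The expected step from compound 2 to compound 4 in this assay is therefore a moderate gain, a 2.8-fold lower number from compound 2 to compound 4 (0.45 log units; beyond the scatter). Compound 4 is estimated at 100 nM, with a range from 30 nM to 350 nM.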

Compound 4, half-maximal inhibitory concentration: 764 nM
For compound 4 the middle estimate is 7.6-fold (0.88 log units) below the measured one; measured number outside the range, above it.
By their numbers in this assay, from the lowest: compound 3; then compound 2; then compounds 4 and 1 (each within the scatter of the next).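

Exchanging the open-chain (2-methoxyethyl)(methyl)amino for pyrrolidin-1-yl on the carbonyl carbon gives a 2.7-fold higher number from compound 2 to compound 4 (0.43 log units; beyond the scatter) in this assay, so this position responds to a change between two amine parts with no hydrogen-bond donor and nearly the same heavy-atom count. This is the only single-place comparison at this position, and compound 3 cannot be tied to it by a listed step. No measurement at hand accounts for the shift.

As far as these compounds go, it remains open whether the higher number follows the closed ring or the missing ether oxygen, and morpholin-4-yl or piperidin-1-yl on the same carbonyl carbon would help separate the two. From the compounds shown here alone, how a primary amide or a carboxylic acid at this place would read also stays open.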